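A few compounds are considered here, and "the series" means these few. Any claim that something is new, unique, unknown or untested is made for them only; others in the source may bear on it.

Working notes on the series. Compound 1, `OC[C@@H](O[C@H]1CCCN(Cc2nc3ccccc3[nH]2)[C@H]1c1ccccc1)c1cc(Cl)cc(Cl)c1`, reaches in an assay on isolated protein for activation of cGMP-dependent protein kinase 1 (Homo sapiens), read by ADP-Glo, with stated times of 30 min and 2 h (a higher number here means that more compound is needed for the effect, a lower number that less compound is needed), only a limit, > 200000 nM; this is the limit (the limit of > 200000 nM in this assay, at which 1 of the 3 values shown sits), and nothing more is said of it. Compound 2, `O=C(O)c1ccc2nc(CN3CCC[C@H](O[C@H](CO)c4cc(Cl)cc(Cl)c4)[C@@H]3c3ccccc3)[nH]c2c1`, gives in this assay a number, 43000 nM. Within the data shown here, the one measured step between compounds that differ in a single place, an at least 4.6-fold lower number from compound 1 to compound 2 (0.66 log units; beyond the scatter), concerns a carboxy group on an aromatic carbon. Compound 3, `COC(=O)Nc1cc(C(=O)O)ccc1CN1CCC[C@H](O[C@H](CO)c2cc(Cl)cc(Cl)c2)[C@@H]1c1ccccc1`, gives in this assay a value of 69000 nM; among the two numbers shown this is the highest, with compound 2 nearest, and the gap between them lies within the usual scatter, so no order between compound 2 and compound 3 can be read from it.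

Compound 4, `Nc1cc(C(=O)O)ccc1CN1CCC[C@H](O[C@H](CO)c2cc(Cl)cc(Cl)c2)[C@@H]1c1ccccc1`, is to be measured. It differs from compound 3 by hydrogen in place of methoxycarbonyl on a nitrogen on an aromatic ring. Among the measured compounds shown here, no measured step touches this group or this position: the step of an at least 4.6-fold lower number from compound 1 to compound 2 (0.66 log units; beyond the scatter) concerns a different group at a different place and so does not bear on the change. For the measured compounds named here, with no step to lean on, the expectation is a step of no size beyond the scatter, so that the estimated step is a 1.2-fold lower number from compound 3 to compound 4 (0.06 log units; within the scatter). Compound 4 is therefore expected to give in this assay about 60000 nM, within a range from 20000 nM to 180000 nM.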

Compound 4, half-maximal effective concentration: 168000 nM
Compound 4: the middle estimate sits 2.8-fold (0.45 log units) below what was measured; the range from low to high includes it.
By their numbers in this assay, from the lowest: compounds 2 and 3 (each within the scatter of the next); then compound 4. At a limit, above all of these: compound 1.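

In this assay, among these compounds, the change from (methoxycarbonyl)amino to amino gives a 2.4-fold higher number from compound 3 to compound 4 (0.39 log units; beyond the scatter): this is the first measured change on this aromatic nitrogen, and it is not silent here, as the number is higher and more compound is needed for the effect. The step of a 3.9-fold higher number from compound 2 to compound 4 (0.59 log units; beyond the scatter) shows the same separation for the group on the saturated chain carbon bound to the ring amine nitrogen, so that compound 4 stands apart from compounds 2 and 3, whose own numbers lie within the scatter of each other. The step of an at least 1.1-fold lower number from compound 1 to compound 4 (0.07 log units; that floor lies within the scatter) cannot be read, as its floor lies within the scatter and compound 1 stands only at a limit: the limit of > 200000 nM in this assay, at which 1 of the 4 values shown sits.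

What the compounds shown leave open is whether the methoxycarbonyl itself matters on this nitrogen, or whether an acetyl or a longer acyl chain there would give a number like that of compound 3. Also open, going by these compounds, is how the carboxylic acid on the phenyl ring contributes, since a methyl ester or a primary amide at that place would be needed to separate it from the change on the nitrogen.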